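A few compounds are considered here, and "the series" means these few. Any claim that something is new, unique, unknown or untested is made for them only; others in the source may bear on it.

In a functional assay on DWD cells (Homo sapiens) for inhibition, read by sulforhodamine B assay (on this read-out lower numbers stand for stronger inhibition of growth and higher numbers for weaker inhibition of growth), compound 1 `COc1ccc(-c2ccc(-c3ccc(-c4nc5cc(C)ccc5[nH]4)cc3)cc2)cc1OC` gives 1720 nM and compound 2 `COc1ccc(-c2ccc(-c3ccc(-c4nc5c(O)cccc5[nH]4)cc3)cc2)cc1OC` gives 1400 nM so the two cannot be told apart, and compound 1 has no clear rank on these numbers. Going by the values given here, the only measured step of a 1.2-fold lower number from compound 1 to compound 2 (0.09 log units; within the scatter) lies within the scatter, and it changes the 5-methyl-1H-benzimidazol-2-yl group, a different place from the one at issue now. Compound 3 `Cc1ccc2[nH]c(-c3ccc(-c4ccc(-c5ccc(F)cc5)cc4)cc3)nc2c1` keeps that group and instead carries 4-fluorophenyl in place of 3,4-dimethoxyphenyl on an aromatic carbon on the same aromatic carbon. Among the compounds with values here, no measured pair tests this swap, so the data give no direction for it and the uncertainty stays wide. With nothing pointing to a large shift in this assay, the expected step of a 1.2-fold higher number from compound 1 to compound 3 (0.07 log units; within the scatter) is no more than the scatter. For compound 3 the estimated value is 2000 nM with an expected range from 600 nM to 7000 nM in this measurement.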

Compound 3, concentration for 50% growth inhibition: 33100 nM
Estimate against measurement, compound 3: 17-fold (1.22 log units) below, outside the stated range (above it).
By their numbers in this assay, from the lowest: compounds 2 and 1 (each within the scatter of the next); then compound 3.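

In this assay, the group on this aromatic carbon clearly matters: replacing 3,4-dimethoxyphenyl with 4-fluorophenyl gives a 19-fold higher number from compound 1 to compound 3 (1.28 log units; beyond the scatter), meaning much weaker inhibition of growth. The only earlier step, a change at a different place, gave a 1.2-fold lower number from compound 1 to compound 2 (0.09 log units; within the scatter), so this is the first change shown to move the read-out beyond the scatter. No measurement at hand offers a reason for this loss.

The swap removes both methoxy groups and adds a fluorine in one move, so the compounds shown cannot separate the effect of losing the methoxy groups from that of gaining the fluorine. As far as these compounds go, it also remains open how this position would respond to 4-methoxyphenyl, which keeps one methoxy group, to plain phenyl, or to a phenyl ring carrying an amine or a carboxylic acid.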